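The source may report more compounds than this note shows. Statements on the series, on what has been measured and on what is new or still open speak of the compounds shown alone.

Measured in a functional assay on HeLa cells (Homo sapiens) for antiproliferative activity, read by MTT assay, with a stated time of 48 h; on this read-out higher numbers stand for weaker inhibition of growth and lower numbers for stronger inhibition of growth:
- Compound 1 `COC(=O)N1N=C(c2cccc(OC)c2)CC1c1cc(OC)c(OC)c(OC)c1`: 1530 nM
- Compound 2 `CCCOC(=O)N1N=C(c2cccc(OC)c2)CC1c1cc(OC)c(OC)c(OC)c1`: > 10000 nM
- Compound 3 `COc1cccc(C2=NN(C(=O)OCc3ccccc3)C(c3cc(OC)c(OC)c(OC)c3)C2)c1`: > 10000 nM

Compound 2 gives > 10000 nM, which is a limit and not a number. Compound 3 gives > 10000 nM, which is also a limit. Together they make up (the limit of > 10000 nM in this assay, at which 2 of the 3 values shown sit).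

Compound 4 `CCCOC(=O)N1N=C(c2ccc(OC)cc2)CC1c1cc(OC)c(OC)c(OC)c1` has the same atoms as compound 2, joined differently: 4-methoxyphenyl in place of 3-methoxyphenyl on a carbon with a double bond to nitrogen.

Two measured steps lead away from compound 1. They are an at least 6.5-fold higher number from compound 1 to compound 2 (0.81 log units; beyond the scatter) and an at least 6.5-fold higher number from compound 1 to compound 3 (0.81 log units; beyond the scatter), both beyond the scatter. The step that the two limits leave unreadable from compound 2 to compound 3 adds no size. None of these steps touches the methoxyphenyl group, so they give no measure for the change at hand. They bear on it only indirectly: the propoxycarbonyl group stays in compound 4, and that group came with an at least 6.5-fold higher number from compound 1 to compound 2 (0.81 log units; beyond the scatter).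

No shift beyond the scatter is therefore expected in this assay, and the expected step is a number no higher from compound 2 to compound 4 (the limit leaves the size open). Another limit is the likeliest report. For compound 4 the estimated value is 10000 nM, with an expected range from 3000 nM to 30000 nM.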

Compound 4, concentration for 50% growth inhibition: > 10000 nM
Compound 4 ended at the assay's limit (the forecaster's own chance of this, stated with the estimate: 65%); the middle value sits exactly at the limit.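

In this assay compound 4 gives > 10000 nM, which is a limit and not a number. No step can be read between compound 2 and compound 4, which both stand at: the limit of > 10000 nM in this assay, at which 3 of the 4 values shown sit. The compounds shown leave open how 4-methoxyphenyl and 3-methoxyphenyl compare on growth inhibition.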